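The compounds below may be only part of what the source reports. "The series", "measured", "known", "first", "only" and "open" are said of these compounds alone.

Working notes on the series. Compound 2 `COc1cccc(N2CCN(C(=O)c3oc(C)nc3-c3ccccc3F)CC2)c1` is measured in a functional assay on HL-60 cells (Homo sapiens) for inhibition, read by MTT assay, with a stated time of 72 h (on this read-out higher numbers stand for weaker inhibition and lower numbers for stronger inhibition), at 56.1 nM, the lowest of the two numbers available; compound 3 `Cc1nc(-c2ccccc2F)c(C(=O)N2CCN(c3cc(Cl)ccc3C)CC2)o1` gives 229 nM, and compound 1 `C=C(C)c1cccc(N2CCN(C(=O)c3oc(C)nc3-c3ccccc3F)CC2)c1` is reported as "not active" (no number reported). Among the compounds with values here, the single step in hand, a 4.1-fold higher number from compound 2 to compound 3 (0.61 log units; beyond the scatter), concerns the group on the amine nitrogen in a ring and not the aryl group attached to the shared core. Compound 4 `COc1cccc(N2CCN(C(=O)c3oc(C)nc3-c3ccccc3)CC2)c1` differs from compound 2 by hydrogen in place of fluoro on an aromatic carbon. Within the data shown here, no measured step touches this position, so the size of the change cannot be read from the series; a shift close to the scatter is expected, direction uncertain, leaning toward a slightly higher number. For compound 4 the estimate in this assay is 90 nM, with a range of 35 nM to 250 nM. This corresponds to an expected 1.6-fold higher number from compound 2 to compound 4 (0.21 log units; within the scatter).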

Compound 4, half-maximal inhibitory concentration: 34.8 nM
Beside the measured number, compound 4's estimate is 2.6-fold (0.41 log units) above it; the measured number lies below the stated range.
By their numbers in this assay, from the lowest: compounds 4 and 2 (each within the scatter of the next); then compound 3.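

In this assay, the change from 2-fluorophenyl to phenyl gives a 1.6-fold lower number from compound 2 to compound 4 (0.21 log units; within the scatter) and so stays within the scatter. Every earlier compound carried the fluoro on this aromatic carbon, and compound 4 shows that a number of this order does not depend on it when the 3-methoxyphenyl group is kept. Nothing available bears on the cause of this result. On these data alone, what trifluoromethyl or an amine on this aromatic carbon would give remains open. So does whether the same swap behaves alike with the 5-chloro-2-methylphenyl group of compound 3.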